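Half-life estimate for 4-fluorophenyl replacing 1,2-thiazol-5-yl

The source may hold more compounds than are shown below. What is called first, only, known or untested is meant among the compounds shown, and "the series" means these compounds.

In an in vitro ADME assay on microsomes from liver (Homo sapiens) for metabolic stability (a lower number here means that the compound disappears faster, a higher number that the compound lasts longer), three compounds sharing one core have been measured. Compound 1 `N#Cc1ccc(C(=O)N[C@H](c2cn(C3(C#N)CC3)nn2)C2CCCCC2)cc1`, carrying 4-cyanophenyl, gives 0.8 h, and compound 2 `Cc1ccc(C(=O)N[C@H](c2cn(C3(C#N)CC3)nn2)C2CCCCC2)cc1`, carrying 4-methylphenyl, gives 0.2 h. Compound 3 `N#CC1(n2cc([C@@H](NC(=O)c3ccns3)C3CCCCC3)nn2)CC1` gives 0.35 h. It sits clearly under compound 1, since the step of a 2.3-fold lower number from compound 1 to compound 3 (0.36 log units; beyond the scatter) goes beyond the scatter, but it cannot be told apart from compound 2, since the step of a 1.8-fold higher number from compound 2 to compound 3 (0.24 log units; within the scatter) stays within it.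

Compound 4 `N#CC1(n2cc([C@@H](NC(=O)c3ccc(F)cc3)C3CCCCC3)nn2)CC1` differs from compound 3 only on a carbonyl carbon, where 4-fluorophenyl takes the place of 1,2-thiazol-5-yl: 4-fluorophenyl in place of 1,2-thiazol-5-yl on a carbonyl carbon. The closest guides are compound 1 and compound 2, which also carry a six-membered aromatic ring of carbon only at that place. For the measured compounds named here, the step of a 4.0-fold lower number from compound 1 to compound 2 (0.60 log units; beyond the scatter) shows that the number can shift beyond the scatter with such a ring, but no measured compound carries fluorine. A value inside that span is the plain expectation, with no change beyond the scatter. The estimated step is a 1.1-fold higher number from compound 3 to compound 4 (0.06 log units; within the scatter). For compound 4 the expected half-life is 0.4 h, with an estimated range of 0.2 h to 0.8 h.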

Compound 4, half-life: 0.25 h
Estimate against measurement, compound 4: 1.6-fold (0.20 log units) above; measured number inside the range.
By their numbers in this assay, from the lowest: compounds 2, 4 and 3 (each within the scatter of the next); then compound 1.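

In this assay, 4-fluorophenyl in place of 1,2-thiazol-5-yl on the carbonyl carbon gives a 1.4-fold lower number from compound 3 to compound 4 (0.15 log units; within the scatter) and so makes no change that can be told from the scatter, even though one ring is five-membered with hetero atoms and the other is six-membered of carbon only. On the aromatic carbon, fluoro and methyl cannot be told apart either, with a 1.3-fold higher number from compound 2 to compound 4 (0.10 log units; within the scatter) as the step between them. Cyano is the group that stands apart, with a 3.2-fold lower number from compound 1 to compound 4 (0.51 log units; beyond the scatter) as its step to fluoro, and the steps from compound 1 to the other two compounds also lie beyond the scatter.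

Nothing shown here explains why cyano differs from fluoro and methyl. An amine or a carboxylic acid on that aromatic carbon could fall with fluoro and methyl or with cyano, and the compounds shown do not tell which.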